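Alkenyl Chain in Place of a Cyanobenzyl Arm

A few compounds are considered here, and "the series" means these few. Any claim that something is new, unique, unknown or untested is made for them only; others in the source may bear on it.

Compound 2 `N#Cc1ccccc1CN1C(=O)N(Cc2ccccc2)S(=O)(=O)n2cccc21` is one of three measured members of a shared core. In an ADME assay on MT4 cells (Homo sapiens) for cytotoxicity, read by MTT assay, with a stated time of 5 days (on this read-out lower numbers stand for higher toxicity in this test and higher numbers for lower toxicity in this test), compound 2 gives > 318000 nM, which is a limit of the assay and not a number. Compound 3 `N#Cc1ccccc1CN1C(=O)N(Cc2cccc(F)c2)S(=O)(=O)n2cccc21` gives > 305000 nM in this assay, again a limit. Compound 1 `O=C1N(Cc2ccccc2Cl)c2cccn2S(=O)(=O)N1Cc1cccc(Br)c1` gives > 260000 nM in this assay, also a limit. Within the data shown here, the single step measured in one place, a step that the two limits leave unreadable from compound 2 to compound 3, thus cannot be read, since both of its ends sit at limits (the limit of > 318000 nM in this assay, at which 1 of the 3 values shown sits, and (the limit of > 305000 nM in this assay, at which 1 of the 3 values shown sits)), and compound 1 stands at the limit of > 260000 nM in this assay, at which 1 of the 3 values shown sits. Compound 4 `O=C1N(C/C=C/c2ccccc2)c2cccn2S(=O)(=O)N1Cc1ccccc1` differs from compound 2 by 2-phenylethenyl in place of 2-cyanophenyl on a saturated chain carbon bound to an amide-type nitrogen in a ring. No measured step bears on this change, and nothing shown separates the three measured compounds from one another in this assay. Compound 4 is therefore expected to show a step of an at least 1.0-fold lower number from compound 2 to compound 4 (0.02 log units; that floor lies within the scatter) that does not go beyond the scatter. The estimate for compound 4 in this assay is 300000 nM, with a range from 100000 nM to 900000 nM, most likely again reported only as a limit.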

Compound 4, half-maximal cytotoxic concentration: > 318000 nM
Compound 4 was reported as a limit; the forecaster's own chance of this, stated with the estimate: 70%; middle value at least 1.0-fold (0.02 log units) from the limit.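

The step from compound 2 to compound 4 cannot be read, because both ends sit at the same limit of the assay, which is not a number: the limit of > 318000 nM in this assay, at which 2 of the 4 values shown sit.

The compounds shown leave open how the four compare in this assay, since each value is only a limit.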